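Removing the chain hydroxy group from compound 3

The source may hold more compounds than are shown below. What is called first, only, known or untested is meant among the compounds shown, and "the series" means these compounds.

Compound 3 `C[C@@H](CC(=O)O)CC(=O)c1c([C@H](O)CCCCCc2ccccc2)n(C)c2ccc(Cl)cc12` gives 750 nM in a functional assay for antagonist activity at Oxoeicosanoid receptor 1 (Homo sapiens), read by fluorescence and calcium flux, with stated times of 2 min and 1 min (on this read-out higher numbers stand for weaker inhibition and lower numbers for stronger inhibition), the highest number among the three measured compounds. Its close relative compound 1 `C[C@@H](CC(=O)O)CC(=O)c1c([C@@H](O)CCCCCc2ccccc2)n(C)c2ccc(Cl)cc12` differs only in configuration and gives 120 nM in this assay; the step from one to the other is a 6.3-fold higher number from compound 1 to compound 3 (0.80 log units; beyond the scatter), which rests on (the fact that compounds 1 and 3 differ only in the configuration as drawn). Compound 4 `C[C@@H](CC(=O)O)CC(=O)c1c(CCCCCCc2ccccc2)n(C)c2ccc(Cl)cc12` is made from compound 3 by hydrogen in place of hydroxy on a saturated chain carbon bound to an aromatic carbon and a saturated chain carbon. Among the compounds with values here, no measured step covers exactly this change, but compound 2 `CC(CC(=O)O)CC(=O)c1c(CCCCCCc2ccccc2)n(C)c2ccc(Cl)cc12`, which lacks the hydroxy group and leaves the methyl-bearing centre undrawn, gives 0.28 nM in this assay. Compound 4 is therefore expected to move strongly toward that number, with an estimated step of a 3000-fold lower number from compound 3 to compound 4 (3.48 log units; beyond the scatter). The estimate for compound 4 is 0.25 nM, with a range from 0.08 nM to 1 nM.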

Compound 4, half-maximal inhibitory concentration: 23 nM
Compound 4: middle estimate off by 92-fold (1.96 log units), on the low side; measured number outside the range, above it.
By their numbers in this assay, from the lowest: compound 2; then compound 4; then compound 1; then compound 3.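

In this assay, hydrogen in place of hydroxy on this saturated chain carbon lowers the number from either hydroxy configuration: a 33-fold lower number from compound 3 to compound 4 (1.51 log units; beyond the scatter) and a 5.2-fold lower number from compound 1 to compound 4 (0.72 log units; beyond the scatter). Even so, compound 4 stays well short of compound 2, with an 82-fold higher number from compound 2 to compound 4 (1.91 log units; beyond the scatter). That gap therefore lies at the other stereocentre, not at the hydroxy position, and it rests on a difference in drawing alone: the fact that one of compounds 2 and 4 is drawn with a defined configuration and the other without, at the place where they differ

Whether the opposite configuration at that stereocentre accounts for the number of compound 2 stays open. So does how a fluorine or an amine in place of the hydroxy would read.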